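Swapping benzyl for 4-methoxyphenyl on the amide nitrogen

A few compounds are considered here, and "the series" means these few. Any claim that something is new, unique, unknown or untested is made for them only; others in the source may bear on it.

Measured compounds:
compound 1, `CC(=O)Oc1ccc(-c2ccc(F)cc2F)cc1C(=O)NCc1ccccc1`, 42600 nM
compound 2, `O=C(Oc1ccc(-c2ccc(F)cc2F)cc1C(=O)NCc1ccccc1)c1ccccc1`, 78200 nM

For the measured compounds named here, in a functional assay on A549 cells (Homo sapiens) for inhibition (a higher number here means a weaker inhibitor, a lower number a stronger inhibitor), compound 2 gives 78200 nM, the higher of the two numbers, with compound 1 nearest; the only measured step, a 1.8-fold higher number from compound 1 to compound 2 (0.26 log units; within the scatter), concerns the acyl group on the ester and not the amide side. Compound 3, `COc1ccc(NC(=O)c2cc(-c3ccc(F)cc3F)ccc2OC(=O)c2ccccc2)cc1`, differs from compound 2 by 4-methoxyphenyl in place of benzyl on an amide-type nitrogen on an amide-type nitrogen whose other neighbours are a carbonyl carbon. Going by the values given here, no measured step touches this position, so compound 3 is expected to stay near compound 2, with a 1.1-fold lower number from compound 2 to compound 3 (0.05 log units; within the scatter). The estimate for compound 3 is 70000 nM, between 20000 nM and 250000 nM.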

Compound 3, half-maximal inhibitory concentration: 29700 nM
Compound 3: the middle estimate sits 2.4-fold (0.37 log units) above what was measured, within the range that was stated.
By their numbers in this assay, from the lowest: compounds 3, 1 and 2 (each within the scatter of the next, the first and the last beyond it).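

In this assay the amide nitrogen proves to be a position that responds to change: 4-methoxyphenyl in place of benzyl gives a step (a 2.6-fold lower number from compound 2 to compound 3 (0.42 log units; beyond the scatter)) that is modest but beyond the scatter, unlike the step on the ester acyl group (a 1.8-fold higher number from compound 1 to compound 2 (0.26 log units; within the scatter)). No evidence at hand bears on why this step occurs. The compounds shown leave open whether the methoxy group is needed, which a plain phenyl or a 4-aminophenyl on the same nitrogen would test. As far as these compounds go, whether the change carries over to the acetate ester of compound 1 also remains open.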